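Swapping the Ring on the Amide-Type Nitrogen

The source may hold more compounds than are shown below. What is called first, only, known or untested is meant among the compounds shown, and "the series" means these compounds.

Of the compounds shown here, three sharing one core have been tested in a functional assay on the whole organism (strain Swiss albino) for inhibition, with Mus musculus as the target, in the formalin test, with stated times of 30 min and 5 min, at a dose of 100 mg/kg; a lower number here means less inhibition, a higher number more inhibition at the dose given (going by the name of the read-out). Compound 1 `CCN1CCc2c(c(C)nn2C(=O)Nc2ccc(Cl)cc2)C1` gives 1.7%, compound 2 `CCN1CCc2c(c(C(C)(C)C)nn2C(=O)Nc2c(C)cccc2C)C1` gives 15.7%, and compound 3 `CCN1CCc2c(c(C(C)(C)C)nn2C(=O)Nc2ccc(F)cc2F)C1` gives 4.4%. Compound 3 thus stands second highest of the three numbers; its value and that of compound 1 lie within the usual scatter of each other, while the gap to compound 2 goes beyond it. Among the measured compounds shown here, the only single-point change measured so far, the move from 2,6-dimethylphenyl to 2,4-difluorophenyl on the amide-type nitrogen, gave a number 11.3 percentage points lower from compound 2 to compound 3 (beyond the scatter).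

Compound 4 `CCN1CCc2c(c(C(C)(C)C)nn2C(=O)Nc2ccc(Cl)cc2)C1` has not yet been measured. It differs from compound 3 in one place: 4-chlorophenyl in place of 2,4-difluorophenyl on an amide-type nitrogen. For the measured compounds named here, no measured step covers exactly this swap. Going by the values given here, the one measured step at the amide-type nitrogen, a number 11.3 percentage points lower from compound 2 to compound 3 (beyond the scatter), shows that exchanging the ring there can move the number by a modest amount. Compound 1 also carries 4-chlorophenyl on the amide-type nitrogen and gives 1.7%, and compound 3 gives 4.4%; both are small numbers within the scatter of each other. Compound 4 is therefore expected to show no step beyond the scatter, with a number 0.6 percentage points higher from compound 3 to compound 4 (within the scatter). The estimate for compound 4 is 5%, with a range from 0% to 15%.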

Compound 4, a percentage reported as inhibition, in the whole organism at one dose (the size of the read-out at that dose, not a potency): 3.5%
The estimate for compound 4 lay 1.5 percentage points above the measured number; the range from low to high includes it.
By their numbers in this assay, from the lowest: compounds 1, 4 and 3 (each within the scatter of the next); then compound 2.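

In this assay the swap on the amide-type nitrogen gives a number 0.9 percentage points lower from compound 3 to compound 4 (within the scatter) and so leaves 2,4-difluorophenyl and 4-chlorophenyl indistinguishable here, while replacing 2,6-dimethylphenyl with 4-chlorophenyl gives a number 12.2 percentage points lower from compound 2 to compound 4 (beyond the scatter) as a second step at this position beyond the scatter. With tert-butyl on the aromatic carbon, compound 2 and its 2,6-dimethylphenyl ring therefore stand apart from both compound 3 and compound 4, which carry halogen-bearing rings. Among the compounds shown here, the first measured step on the aromatic carbon, tert-butyl in place of methyl, gives a number 1.8 percentage points higher from compound 1 to compound 4 (within the scatter) and thus shows no separation between those two groups when 4-chlorophenyl sits on the amide-type nitrogen.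

Still open, going by these compounds, is whether an amine or a carboxylic acid on the ring, or a longer chain in place of the ring on the amide-type nitrogen, would move the number, and whether methyl in place of tert-butyl would matter with 2,6-dimethylphenyl on that nitrogen. No measurement at hand accounts for the separation of compound 2 from compound 3 and compound 4.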